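Chain amine swap on the shared core: pyrrolidinyl to methylpiperazinyl

The compounds below may be only part of what the source reports. "The series", "measured", "known", "first", "only" and "open" are said of these compounds alone.

Compound 3 `COc1ccc(-n2nc(C(=O)Nc3ccc(Oc4ccnc5cc(OCCCN6CCCC6)c(OC)cc45)c(F)c3)c(C)cc2=O)cc1` gives 1290 nM in a functional assay on MKN-45 cells (Homo sapiens) for inhibition, read by MTT assay, with a stated time of 72 h (a lower number here means a stronger inhibitor, a higher number a weaker inhibitor), the second highest of the three numbers; compound 1 `COc1cc2c(Oc3ccc(NC(=O)c4nn(-c5ccccc5C)c(=O)cc4C)cc3F)ccnc2cc1OCCCN1CCN(C)CC1` at 1630 nM sits within the scatter of it, while compound 2 `COc1cc2c(Oc3ccc(NC(=O)c4nn(-c5ccccc5C(F)(F)F)c(=O)cc4C)cc3F)ccnc2cc1OCCCN1CCN(C)CC1` at 40 nM lies far lower. For the measured compounds named here, the only single-point step measured, a 41-fold lower number from compound 1 to compound 2 (1.61 log units; beyond the scatter), concerns the aryl substituent and does not touch the chain amine. Compound 4 `COc1ccc(-n2nc(C(=O)Nc3ccc(Oc4ccnc5cc(OCCCN6CCN(C)CC6)c(OC)cc45)c(F)c3)c(C)cc2=O)cc1` differs from compound 3 by 4-methylpiperazin-1-yl in place of pyrrolidin-1-yl on a saturated chain carbon, three bonds along the chain from an oxygen on an aromatic ring. Going by the values given here, no measured pair isolates this change; compounds 1 and 2 carry the methylpiperazinyl chain, compound 3 the pyrrolidinyl one, but each also differs elsewhere. With nothing to support a shift, no step beyond the scatter is expected, a 1.1-fold lower number from compound 3 to compound 4 (0.03 log units; within the scatter). Compound 4 is therefore estimated at 1200 nM, within 450 nM to 3200 nM.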

Compound 4, half-maximal inhibitory concentration: 1230 nM
The estimate for compound 4 lay 1.0-fold (0.01 log units) below the measured number, within the range that was stated.
By their numbers in this assay, from the lowest: compound 2; then compounds 4, 3 and 1 (each within the scatter of the next).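

In this assay the chain amine position takes 4-methylpiperazin-1-yl in place of pyrrolidin-1-yl with a 1.0-fold lower number from compound 3 to compound 4 (0.02 log units; within the scatter) and no shift beyond the scatter, now seen as a single change. On the aromatic nitrogen, 4-methoxyphenyl in place of 2-(trifluoromethyl)phenyl gives a 31-fold higher number from compound 2 to compound 4 (1.49 log units; beyond the scatter) while 4-methoxyphenyl in place of 2-methylphenyl gives a 1.3-fold lower number from compound 1 to compound 4 (0.12 log units; within the scatter) and stays within the scatter. Nothing measured here accounts for either outcome. Still open, as far as these compounds go, is whether the chain swap stays flat with 2-(trifluoromethyl)phenyl on the aromatic nitrogen, and how a morpholine or dimethylamine at the chain end would read.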